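Amine-linked aryl groups on the shared core: cytotoxicity notes

The source may report more compounds than this note shows. Statements on the series, on what has been measured and on what is new or still open speak of the compounds shown alone.

Measured so far in an ADME assay on MDCK cells (Canis lupus familiaris) for cytotoxicity, read by microscopy, with a stated time of 48 h; on this read-out higher numbers stand for lower toxicity in this test and lower numbers for higher toxicity in this test:
Compound 1 `C[C@H]1[C@H](NCc2ccc(Cl)s2)C[C@H]2C[C@@H]1C2(C)C` gives 25000 nM.
Compound 3 `C[C@H]1[C@H](NCc2cccs2)C[C@H]2C[C@@H]1C2(C)C` gives 25000 nM.
For compound 2 `C[C@H]1[C@H](NCc2cncnc2)C[C@H]2C[C@@H]1C2(C)C` the result is only a limit of this assay, > 100000 nM.

Compound 3 stands level with compound 1 at the digits shown; the step of no change at the digits printed from compound 1 to compound 3 (within the scatter) lies within the scatter, so hydrogen in place of chloro on the aromatic carbon leaves the read-out unmoved here. Compound 4 `C[C@H]1[C@H](NCc2ccoc2)C[C@H]2C[C@@H]1C2(C)C` differs from compound 3 by furan-3-yl in place of thiophen-2-yl on a saturated chain carbon bound to an amine nitrogen. Within the data shown here, two measured steps bear on a change of the aryl group at this place: an at least 4.0-fold higher number from compound 1 to compound 2 (0.60 log units; beyond the scatter) and an at least 4.0-fold lower number from compound 2 to compound 3 (0.60 log units; beyond the scatter), both involving (the limit of > 100000 nM in this assay, at which 1 of the 3 values shown sits). The present exchange swaps one five-membered aromatic ring with 1 hetero atom for another of the same make-up, a smaller change than the move to pyrimidin-5-yl. No step beyond the scatter is therefore expected, and the estimated step is a 1.3-fold higher number from compound 3 to compound 4 (0.11 log units; within the scatter). Compound 4 is estimated at 32000 nM in this assay, with a range from 12000 nM to 100000 nM.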

Compound 4, minimum cytotoxic concentration: > 100000 nM
Compound 4: a limit, no number; the forecaster's own chance of this, stated with the estimate: 20%; at least 3.1-fold (0.49 log units) between middle value and limit.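

Pyrimidin-5-yl is no longer the only group at this place to go with a higher number: in this assay, an at least 4.0-fold higher number from compound 3 to compound 4 (0.60 log units; beyond the scatter) and an at least 4.0-fold higher number from compound 1 to compound 4 (0.60 log units; beyond the scatter), so exchanging one five-membered aromatic ring with 1 hetero atom for another is enough to move the read-out beyond the scatter. Compound 4 gives > 100000 nM, which is a limit of the assay and not a number. Compound 2 and compound 4 are both limits, so the step between them cannot be read: the limit of > 100000 nM in this assay, at which 2 of the 4 values shown sit.

The exchange changes both the hetero atom, sulfur to oxygen, and the point of attachment, and the compounds shown do not separate the two; thiophen-3-yl or furan-2-yl at this place would do so. As far as these compounds go, how far compound 2 and compound 4 lie beyond their limits also stays open.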